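This account rests on a few compounds, and the source may have more. Where it says the series, first, only, none or still open, it means among the compounds named here.

Series notes. Compound 1 `CC(C)(C)OC(=O)NCCCCNCCCN(Cc1ccc(-c2ccccc2)cc1)Cc1ccc(-c2ccccc2)cc1` carries a tert-butoxycarbonyl group on a chain amine; compound 2 `NCCCCNCCCN(Cc1ccc(-c2ccccc2)cc1)Cc1ccc(-c2ccccc2)cc1` lacks it. In an ADME assay on RAW264.7 cells (Mus musculus) for cytotoxicity, read by resazurin assay, with a stated time of 48 h (a lower number here means that less compound is tolerated, a higher number that more compound is tolerated), compound 1 gives only a limit, > 100000 nM. Compound 2 gives 4200 nM in this assay. The change hydrogen in place of tert-butoxycarbonyl on an amine nitrogen thus produced an at least 23-fold lower number from compound 1 to compound 2 (1.37 log units; beyond the scatter). The true size of that step is not fixed, since compound 1 sits at the limit (the limit of > 100000 nM in this assay, at which 1 of the 3 values shown sits).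

Compound 3 `CC(C)(C)OC(=O)NCCCCN(CCCN(Cc1ccccc1)Cc1ccccc1)CCCN(Cc1ccccc1)Cc1ccccc1` has a different core; the difference between the two cores is not broken down here. In this assay compound 3 gives 12500 nM. Compound 4 `NCCCCN(CCCN(Cc1ccccc1)Cc1ccccc1)CCCN(Cc1ccccc1)Cc1ccccc1` has not been measured. It stands to compound 3 as compound 2 stands to compound 1, the same change at the same kind of place: hydrogen in place of tert-butoxycarbonyl on an amine nitrogen.

For compound 4 the expected step is an 8.3-fold lower number from compound 3 to compound 4 (0.92 log units; beyond the scatter). This expectation rests on the measured step of an at least 23-fold lower number from compound 1 to compound 2 (1.37 log units; beyond the scatter) and on compound 3 at 12500 nM; with a single measured example of the change, the range is kept wide. Compound 4 is expected to give around 1500 nM, between 500 nM and 6000 nM.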

Compound 4, half-maximal cytotoxic concentration: 1200 nM
Compound 4: the middle estimate sits 1.3-fold (0.10 log units) above what was measured; the measured number falls inside the stated range.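

Removing tert-butoxycarbonyl from the amine nitrogen again gives a lower number in this assay, a 10-fold lower number from compound 3 to compound 4 (1.02 log units; beyond the scatter). The change therefore runs in the same direction on both cores, and in both pairs the compound with the free amino group is tolerated at the lower concentration: the same change on two cores in this assay, an at least 23-fold lower number (1.37 log units; beyond the scatter) from compound 1 to compound 2 and a 10-fold lower number (1.02 log units; beyond the scatter) from compound 3 to compound 4; the limit leaves it open whether they differ. These two pairs establish no rule for other cores in the series, and the size of the step on the core of compound 1 stays unfixed, since that compound's value is only a limit: the limit of > 100000 nM in this assay, at which 1 of the 4 values shown sits.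

The compounds shown leave open whether the lower number depends on the free amino group itself, or whether an acetyl amide or a methyl carbamate on the same nitrogen would behave like tert-butoxycarbonyl. They also leave open whether a longer chain ending in an amine, or a carboxylic acid at the chain end, would shift the number on either core.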